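Ring-opened hydroxy analogue of the indanol amine

This account rests on a few compounds, and the source may have more. Where it says the series, first, only, none or still open, it means among the compounds named here.

Compound 1 `O[C@@H]1Cc2ccccc2[C@H]1NC1CCN(CCCc2c[nH]c3ccc(-n4cnnc4)cc23)CC1` stands highest of the two numbers measured in an assay on CHO cells for agonist activity at 5-hydroxytryptamine receptor 1D (Homo sapiens), read by GTPgammaS binding (on this read-out lower numbers stand for an effect already at smaller amounts and higher numbers for an effect only at larger amounts of compound), where compound 1 gives 13 nM. Within the data shown here, compound 2 `COC[C@H](NC1CCN(CCCc2c[nH]c3ccc(-n4cnnc4)cc23)CC1)c1ccccc1`, the only other measured member, gives 0.9 nM in this assay; the single measured step, a 14-fold lower number from compound 1 to compound 2 (1.16 log units; beyond the scatter), lies well beyond the scatter and in the direction of an effect at smaller amounts. Compound 3 `OCCC(NC1CCN(CCCc2c[nH]c3ccc(-n4cnnc4)cc23)CC1)c1ccccc1` has not yet been measured in this assay. It differs from compound 1 as 3-hydroxy-1-phenylpropyl in place of 2-hydroxy-2,3-dihydro-1H-inden-1-yl on an amine nitrogen. The group that enters keeps the one hydrogen-bond donor and one hydrogen-bond acceptor counted for the group that leaves, but loses the five-membered non-aromatic ring and carries the phenyl on an open chain. The step that bears on this is a 14-fold lower number from compound 1 to compound 2 (1.16 log units; beyond the scatter), in which 2-methoxy-1-phenylethyl replaced the same 2-hydroxy-2,3-dihydro-1H-inden-1-yl group. Compound 3 is therefore expected to move in the same direction, by a 4.3-fold lower number from compound 1 to compound 3 (0.64 log units; beyond the scatter). Among the measured compounds shown here, no measured step compares a hydroxyl with a methoxy or one chain length with another, so the expected step is kept smaller than the one seen. For compound 3 the estimate in this assay is 3 nM, within 0.8 nM to 12 nM.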

Compound 3, half-maximal effective concentration: 5.1 nM
The estimate for compound 3 lay 1.7-fold (0.23 log units) below the measured number; the measured number falls inside the stated range.
By their numbers in this assay, from the lowest: compound 2; then compound 3; then compound 1.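

In this assay, an open chain on the amine nitrogen does not need the methoxy group of compound 2 to improve on compound 1: with 3-hydroxy-1-phenylpropyl, which keeps the hydroxyl and the heavy-atom count of 2-hydroxy-2,3-dihydro-1H-inden-1-yl, the result is a 2.5-fold lower number from compound 1 to compound 3 (0.41 log units; beyond the scatter) in a modest step. Opening the five-membered non-aromatic ring therefore goes with only part of the change seen with 2-methoxy-1-phenylethyl, and the two open-chain groups are themselves separated by a 5.7-fold higher number from compound 2 to compound 3 (0.75 log units; beyond the scatter) beyond the scatter. Nothing available explains either step.

The step between compound 2 and compound 3 changes methoxy to hydroxyl and also alters the chain, so 2-hydroxy-1-phenylethyl and 3-methoxy-1-phenylpropyl would be needed to separate these two changes, and the defined stereocentre of compound 2 adds a further unresolved difference from compound 3. Going by these compounds, how this assay responds to an amine in place of the hydroxyl, or to the longer 4-hydroxy-1-phenylbutyl chain, also remains open.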